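Methylamino in Place of Propylsulfanyl on a Diphosphate Agonist

A few compounds are considered here, and "the series" means these few. Any claim that something is new, unique, unknown or untested is made for them only; others in the source may bear on it.

Compound 1, `CNc1nc(=O)ccn1[C@@H]1O[C@H](COP(=O)(O)O)[C@@H](O)[C@H]1O`: in an in vitro functional assay on 1321-N1 cells for agonist activity at P2Y purinoceptor 4 (Homo sapiens), read by scintillation proximity assay and inositol phosphate accumulation (on this read-out lower numbers stand for an effect already at smaller amounts and higher numbers for an effect only at larger amounts of compound), compound 1 gives > 100000 nM, which is a limit of the assay, not a number.
Compound 2, `CCCSc1nc(=O)ccn1[C@@H]1O[C@H](COP(=O)(O)OP(=O)(O)O)[C@@H](O)[C@H]1O`: in this assay compound 2 gives 4900 nM.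

For the measured compounds named here, compound 2 therefore holds the only measured number; the other value sits at a limit, (the limit of > 100000 nM in this assay, at which 1 of the 2 values shown sits). Compound 3, `CNc1nc(=O)ccn1[C@@H]1O[C@H](COP(=O)(O)OP(=O)(O)O)[C@@H](O)[C@H]1O`, differs from compound 2 by methylamino in place of propylsulfanyl on an aromatic carbon. Going by the values given here, no pair of measured compounds shows this change, so its effect in this assay is unknown. Compound 3 is expected to need larger amounts than compound 2, a step of a 3.1-fold higher number from compound 2 to compound 3 (0.49 log units; beyond the scatter). The estimate for compound 3 is 15000 nM, within a range from 4000 nM to 60000 nM.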

Compound 3, half-maximal effective concentration: >= 100000 nM
Compound 3 ended at the assay's limit; the forecaster's own chance of this, stated with the estimate: 25%; at least 6.6-fold (0.82 log units) between middle value and limit.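

For the compounds shown here, on the aromatic carbon between two ring nitrogen atoms, methylamino in place of propylsulfanyl gives the first readable step in this assay, an at least 20-fold higher number from compound 2 to compound 3 (1.30 log units; beyond the scatter), so the group at this carbon matters for the diphosphate series. The step from compound 1 to compound 3 cannot be read. Compound 3 stands at a limit of the assay, not a number: the limit of >= 100000 nM in this assay, at which 1 of the 3 values shown sits.

Still open, as far as these compounds go, is whether the change of sulfur to nitrogen or the shorter chain drives the step. Propylamino or methylsulfanyl on this carbon would separate the two.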